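Changing the Aromatic Group on the Ring Nitrogen

This account rests on a few compounds, and the source may have more. Where it says the series, first, only, none or still open, it means among the compounds named here.

Compound 1, `CCCc1nc(-c2ccccc2)c(CNCCCN2CCN(c3ccccc3F)CC2)o1`: 54.4%
Compound 2, `CCCc1nc(-c2ccccc2)c(CNCCCN2CCN(c3cccc(Cl)c3)CC2)o1`: 65.9%

Both compounds were tested in an assay on HEK293 cells for inhibition of Voltage-dependent T-type calcium channel subunit alpha-1G (Homo sapiens), read by fluorescence, tested at 10 uM; a higher number here means more inhibition at the concentration tested (going by the name of the read-out), a lower number less inhibition. Compound 2 holds the higher of the two numbers; the step of a number 11.5 percentage points higher from compound 1 to compound 2 (beyond the scatter) lies beyond the usual scatter, so compound 2 stands clearly above compound 1. Compound 3, `CCCc1nc(-c2ccccc2)c(CNCCCN2CCN(c3ccccc3C)CC2)o1`, differs from compound 2 by 2-methylphenyl in place of 3-chlorophenyl on an amine nitrogen in a ring. Among the measured compounds shown here, only one measured step, a number 11.5 percentage points higher from compound 1 to compound 2 (beyond the scatter), bears on this change, and it bears loosely: it compares a 2-fluorophenyl with a 3-chlorophenyl group, while compound 3 carries a 2-methylphenyl group that matches neither. With so little to go on, the expectation for compound 3 is a modest downward step, a number 7.9 percentage points lower from compound 2 to compound 3 (within the scatter), landing between the two measured values. Compound 3 is therefore estimated at 58%, with a range from 40% to 76%.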

Compound 3, a percentage reported as inhibition, at one concentration (the size of the read-out at that concentration, not a potency): 54.5%
For compound 3 the middle estimate is 3.5 percentage points above the measured one; the measured number falls inside the stated range.
By their numbers in this assay, from the lowest: compounds 1 and 3 (each within the scatter of the next); then compound 2.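

Putting 2-methylphenyl in place of 3-chlorophenyl on the amine nitrogen in the ring gives a number 11.4 percentage points lower from compound 2 to compound 3 (beyond the scatter) in this assay, so compound 2 now stands clearly above two close relatives, not just one. Methyl in place of fluoro on the aromatic carbon gives a number 0.1 percentage points higher from compound 1 to compound 3 (within the scatter), so the 2-fluorophenyl and 2-methylphenyl groups cannot be told apart in this assay. Nothing available explains why these numbers fall as they do.

The compounds shown change the atom and its place on the phenyl ring together, so they leave open whether the higher number of compound 2 goes with the chlorine or with its place. A 2-chlorophenyl or a 3-methylphenyl group on the same nitrogen would separate the two.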